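Moving the bromine around the phenoxy ring of compound 3

The compounds below may be only part of what the source reports. "The series", "measured", "known", "first", "only" and "open" are said of these compounds alone.

The three measured compounds share one core and differ only in the aryl group at the far end of the oxygen-linked chain. In a functional assay on HepG2 cells (Homo sapiens) for antiproliferative activity, read by MTT assay, with a stated time of 72 h (a lower number here means a stronger inhibitor, a higher number a weaker inhibitor), compound 1 `NC1=NC2(CCSCC2)N(OCCCOc2ccc(Cl)c(Cl)c2)C(N)=N1` gives 70 nM and compound 2 `CC(C)(C)c1ccc(OCCCON2C(N)=NC(N)=NC23CCSCC3)cc1` gives 70 nM. Compound 3 `NC1=NC2(CCSCC2)N(OCCCOc2ccc(Br)cc2)C(N)=N1` gives 1400 nM, the highest of the three numbers; the steps of a 20-fold higher number from compound 1 to compound 3 (1.30 log units; beyond the scatter) and a 20-fold higher number from compound 2 to compound 3 (1.30 log units; beyond the scatter) are both large, so compound 3 is the weakest of the measured set. Compound 4 `NC1=NC2(CCSCC2)N(OCCCOc2ccccc2Br)C(N)=N1` differs from compound 3 only in this way: 2-bromophenyl in place of 4-bromophenyl on an oxygen on a saturated carbon. Among the compounds with values here, no measured step moves a bromine between two places on the same ring, so there is no direct guide, and a step within the scatter is expected. Compound 4 is therefore estimated at 1400 nM (range 400 nM to 5000 nM), an expected step of no change at the digits printed from compound 3 to compound 4 (within the scatter).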

Compound 4, half-maximal inhibitory concentration: 90 nM
Compound 4: the middle estimate sits 16-fold (1.19 log units) above what was measured; the measured number lies below the stated range.
By their numbers in this assay, from the lowest: compounds 1, 2 and 4 (each within the scatter of the next); then compound 3.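

Moving the bromine alone, with the same atoms joined differently, gives a 16-fold lower number from compound 3 to compound 4 (1.19 log units; beyond the scatter) in this assay and so shows that its place on the ring matters at this end of the chain, not just which group is present. With 2-bromophenyl in place of 3,4-dichlorophenyl, the result is a 1.3-fold higher number from compound 1 to compound 4 (0.11 log units; within the scatter) and these two compounds cannot be told apart here. Nothing available explains the effect of moving the bromine. Going by these compounds, whether a chlorine or a methoxy group could replace the bromine of compound 4 and give a similar number remains open, as does the effect of a longer chain.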